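Dimethoxyphenyl in Place of Methylphenyl on the Anilino Nitrogen

The source may report more compounds than this note shows. Statements on the series, on what has been measured and on what is new or still open speak of the compounds shown alone.

Compound 1 `FC(F)(F)c1ccc(CSc2nc(Nc3cccc(Cl)c3)c3ccccc3n2)cc1` gives 18000 nM in a functional assay on MDA-MB-231 cells (Homo sapiens) for cytotoxicity, read by MTT assay, with a stated time of 72 h; on this read-out higher numbers stand for weaker inhibition and lower numbers for stronger inhibition. Compound 2 `Cc1ccc(Nc2nc(SCc3ccc(C(F)(F)F)cc3)nc3ccccc23)cc1` carries 4-methylphenyl in place of 3-chlorophenyl on a nitrogen on an aromatic ring. In this assay compound 2 reaches only a limit, > 50000 nM, so no number is known for it. The step of an at least 2.7-fold higher number from compound 1 to compound 2 (0.44 log units; beyond the scatter) is therefore itself only a lower bound. Compound 2 thus sits at the weak end of the two values, at the limit of > 50000 nM in this assay, at which 1 of the 2 values shown sits.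

Compound 3 `COc1ccc(Nc2nc(SCc3ccc(C(F)(F)F)cc3)nc3ccccc23)cc1OC` differs from compound 2 in one place: 3,4-dimethoxyphenyl in place of 4-methylphenyl on a nitrogen on an aromatic ring. For the measured compounds named here, the only measured step that bears on a change at this nitrogen is an at least 2.7-fold higher number from compound 1 to compound 2 (0.44 log units; beyond the scatter), which shows that such a swap can move the read-out, but its size is itself capped by the limit. With compound 2 at a limit, the expected step of an at least 1.1-fold lower number from compound 2 to compound 3 (0.04 log units; that floor lies within the scatter) cannot be sized with confidence and is taken as no clear change beyond the scatter. Compound 3 is estimated at 45000 nM, within 12000 nM to 160000 nM.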

Compound 3, half-maximal inhibitory concentration: 18900 nM
For compound 3 the middle estimate is 2.4-fold (0.38 log units) above the measured one; the range from low to high includes it.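

In this assay, 3,4-dimethoxyphenyl on a nitrogen on an aromatic ring gives a measured value where 4-methylphenyl gave only a limit, with an at least 2.6-fold lower number from compound 2 to compound 3 (0.42 log units; beyond the scatter). So a measurable value at this position does not depend on the 3-chlorophenyl group of compound 1, and a ring carrying two hydrogen-bond acceptors is compatible with one: a 1.1-fold higher number from compound 1 to compound 3 (0.02 log units; within the scatter), so these two groups cannot be told apart here. The size of the step from the methylphenyl compound remains only a bound, since compound 2 stands at a limit of the assay: the limit of > 50000 nM in this assay, at which 1 of the 3 values shown sits.

The compounds shown leave open whether a single methoxy group on the phenyl ring would be enough to give a measurable value. They also leave open what a carboxylic acid or an amine on that ring would do.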